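A few compounds are considered here, and "the series" means these few. Any claim that something is new, unique, unknown or untested is made for them only; others in the source may bear on it.

Measured in a functional assay for inhibition, with Homo sapiens as the target (on this read-out higher numbers stand for an effect only at larger amounts of compound and lower numbers for an effect already at smaller amounts), so far:
- compound 1 `CCCCC(=O)Nc1ccc(C2=NNC(=O)CC2)cc1` gives 2.64 ug/mL
- compound 2 `CCCNCC(=O)Nc1ccc(C2=NNC(=O)CC2)cc1` gives about 46.4 ug/mL

Compound 2 holds the higher of the two numbers, so it needs the larger amount of compound for an effect. For the measured compounds named here, the only measured step is large and beyond the scatter: an 18-fold higher number from compound 1 to compound 2 (1.24 log units; beyond the scatter) as propylamino replaces propyl.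

Compound 3 `C[N+]1(CC(=O)Nc2ccc(C3=NNC(=O)CC3)cc2)CCCC1` is changed at that same place, on a saturated chain carbon bound to a carbonyl carbon. There, a group of 6 heavy atoms (5 carbon, 1 nitrogen; one five-membered non-aromatic ring with 1 hetero atom) in place of a group of 4 heavy atoms (3 carbon, 1 nitrogen; no ring), on a saturated chain carbon bound to a carbonyl carbon is the difference, and the entering group has one five-membered non-aromatic ring and net charge +1.

Going by the values given here, the measured step is the only guide, and it brought nitrogen into the chain. Compound 3 keeps nitrogen there, as does compound 2 at about 46.4 ug/mL and so a second jump of that size is not expected. Among the compounds with values here, no measured compound carries a net charge, so the direction stays uncertain. The expected step is a 1.5-fold higher number from compound 2 to compound 3 (0.18 log units; within the scatter) and no clear move beyond the scatter is expected in this assay here. The estimated value for compound 3 is 70 ug/mL with an expected range from 20 ug/mL to 250 ug/mL in this assay.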

Compound 3, half-maximal effective concentration: > 46.4 ug/mL
Compound 3 ended at the assay's limit (the forecaster's own chance of this, stated with the estimate: 25%); the middle value lies beyond the limit too.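

In this assay compound 3 gives > 46.4 ug/mL, which is a limit of the assay and not a number. Putting the group with the five-membered non-aromatic ring and net charge +1 on the saturated chain carbon bound to a carbonyl carbon gives an at least 17-fold higher number from compound 1 to compound 3 (1.24 log units; beyond the scatter), so the large move away from the propyl of compound 1 is no longer tied to propylamino alone: two different nitrogen-bearing groups at this place now share it. The remaining step is a number no lower from compound 2 to compound 3 (the limit leaves the size open), so nothing can be said about how far apart these two nitrogen-bearing groups lie, only that compound 3 sits at a limit: the limit of > 46.4 ug/mL in this assay, at which 1 of the 3 values shown sits.

Nitrogen, ring and net charge all enter together in compound 3, so the compounds shown cannot separate what each of them contributes to the higher numbers. They also leave open how a plain pyrrolidine ring without the extra methyl, a carboxylic acid, or an all-carbon chain longer than propyl would read at this place, and whether any group there could give a number lower than that of compound 1.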